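Swapping the Heteroaryl Arm on a Weak Piperidine Ether

The source may hold more compounds than are shown below. What is called first, only, known or untested is meant among the compounds shown, and "the series" means these compounds.

Measured compounds:
compound 1 `OC[C@@H](O[C@H]1CCCN(Cc2ncc[nH]2)[C@H]1c1ccccc1)c1cc(Cl)cc(Cl)c1`, 7000 nM
compound 2 `Clc1cc(Cl)cc(CO[C@H]2CCCN(Cc3ccccn3)[C@H]2c2ccccc2)c1`, > 200000 nM
compound 3 `OC[C@@H](O[C@H]1CCCN(Cc2cccc3nonc23)[C@H]1c1ccccc1)c1cc(Cl)cc(Cl)c1`, 8000 nM

All three share a piperidine core that carries a phenyl group and a dichlorophenyl ether, and they are compared in an assay on isolated protein for activation of cGMP-dependent protein kinase 1 (Homo sapiens), read by ADP-Glo, with stated times of 120 min and 40 min; a higher number here means that more compound is needed for the effect, a lower number that less compound is needed. In this assay compound 2 gives > 200000 nM, which is a limit of the assay rather than a number. Compound 2 therefore sits at the weak edge of what can be read, the place marked by the limit of > 200000 nM in this assay, at which 1 of the 3 values shown sits. Compound 1 and compound 3, which carry a hydroxymethyl group on the ether carbon, give numbers that can be read.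

Compound 4 `Cn1ccnc1CN1CCC[C@H](OCc2cc(Cl)cc(Cl)c2)[C@@H]1c1ccccc1` is not yet measured. It differs from compound 2 in one place: 1-methyl-1H-imidazol-2-yl in place of pyridin-2-yl on a saturated chain carbon bound to an amine nitrogen in a ring. Within the data shown here, the only measured step of the same kind, a change of the aromatic arm on the saturated chain carbon bound to the ring amine nitrogen, is a 1.1-fold higher number from compound 1 to compound 3 (0.06 log units; within the scatter). That step stayed within the scatter, so exchanging this arm did little there. Compound 4 is therefore expected to stay close to compound 2, with a number no higher from compound 2 to compound 4 (the limit leaves the size open) as the expected step and a good chance that only a limit is read again. The estimate for compound 4 in this assay is 200000 nM, ranging from 50000 nM to 600000 nM.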

Compound 4, half-maximal effective concentration: 165000 nM
For compound 4 the middle estimate is 1.2-fold (0.08 log units) above the measured one, and the stated range covers the measured number.
By their numbers in this assay, from the lowest: compounds 1 and 3 (each within the scatter of the next); then compound 4. At a limit, above all of these: compound 2.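

Among these compounds, exchanging pyridin-2-yl for 1-methyl-1H-imidazol-2-yl on a saturated chain carbon bound to an amine nitrogen in a ring gives, for the first time among the compounds without the hydroxymethyl group, a value that can be read in this assay. The change amounts to an at least 1.2-fold lower number from compound 2 to compound 4 (0.08 log units; that floor lies within the scatter), so the printed step alone does not establish a real gain, though the true step could be larger. As far as these compounds go, its size stays open because compound 2 gives only a limit of the assay, not a number: the limit of > 200000 nM in this assay, at which 1 of the 4 values shown sits.

It remains open whether the methyl group on the new arm matters at this position, or whether adding the hydroxymethyl group to compound 4 would change its number, since no compound shown differs from compound 4 in only one of these ways. Also open, from the compounds shown here alone, is how an arm carrying a carboxylic acid or a primary amine, or a longer chain in place of the saturated chain carbon, would read in this assay.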